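The source may hold more compounds than are shown below. What is called first, only, known or untested is meant among the compounds shown, and "the series" means these compounds.

Measured compounds:
- compound 1, `CC(C)CCn1nc(-c2cccs2)c(O)c(C2=NS(=O)(=O)c3cc(N(C(C)C)S(C)(=O)=O)ccc3N2)c1=O`: "not determined" (no result reported) in an ADME assay on Huh-7 cells (Homo sapiens) for cytotoxicity, with a stated time of 72 h; on this read-out higher numbers stand for lower toxicity in this test and lower numbers for higher toxicity in this test
- compound 2, `CC(C)CCn1nc(C2CCCCC2)c(O)c(C2=NS(=O)(=O)c3cc(NS(C)(=O)=O)ccc3N2)c1=O`: > 1000 nM in this assay

Compound 2 stands at the edge of what the numbers show. In this assay compound 2 gives > 1000 nM, which is a limit of the assay rather than a measured number. Within the data shown here, the other measured entry, compound 1, carries no value at all, so nothing gives a second fixed point, and no step between measured compounds can be drawn. Among the measured compounds shown here, the only evidence on where the series sits is the limit of > 1000 nM in this assay, at which 1 of the 2 values shown sits.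

The next compound, compound 3, is `CC(C)CCc1nn(CCC(C)C)c(=O)c(C2=NS(=O)(=O)c3cc(NS(C)(=O)=O)ccc3N2)c1O`. Against compound 2 the change is isopentyl in place of cyclohexyl on an aromatic carbon. This is a swap of one saturated carbon group for another of similar size at the same place on the core of compound 2, with no change in donors, acceptors or charge.

Given that compound 2 sits at the limit, the expected step from compound 2 to compound 3 in this assay is a step that the limit leaves unreadable from compound 2 to compound 3, that is none beyond the scatter. Compound 3 is therefore expected to give about 5000 nM in this assay, with a range from 1000 nM to 30000 nM, and most likely to be reported only as a limit again.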

Compound 3, half-maximal cytotoxic concentration: > 33000 nM
Compound 3: only a limit was reported; the forecaster's own chance of this, stated with the estimate: 80%; at least 6.6-fold (0.81 log units) between middle value and limit.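

In this assay compound 2 gives > 1000 nM, which is a limit. Among these compounds, compound 3 gives > 33000 nM, again a limit, so no step between compound 2 and compound 3 can be read. Still open, on these data alone, is where the actual values of these two compounds lie in this assay, and whether isopentyl in place of cyclohexyl on an aromatic carbon changes the read-out at all.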